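The compounds below may be only part of what the source reports. "The series", "measured", "known", "first", "only" and "open" are said of these compounds alone.

Compound 1 `CN(C)CCN(CCN(C)C)c1cccc(C(=O)N2CCc3ccc(OS(N)(=O)=O)cc3C2)c1` is one of three compounds that have been measured in an assay on HEK293 cells for inhibition of Steryl-sulfatase (Homo sapiens), tested at 0.1 uM; a higher number here means a stronger effect of the compound at the concentration tested, a lower number a weaker effect. In this assay compound 1 gives 0%, the lowest of the three numbers. Compound 3 `NS(=O)(=O)Oc1ccc2c(c1)CN(C(=O)c1ccc(N(CCCO)Cc3ccccc3)cc1)CC2` gives 5.7% in this assay, a number that lies within the usual scatter of compound 1, so the two cannot be told apart. Compound 2 `CCN(Cc1ccccn1)c1ccc(C(=O)N2CCc3ccc(OS(N)(=O)=O)cc3C2)cc1` gives 42.5% in this assay, a number beyond the scatter above compound 1, and only here is a real difference seen.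

Compound 4 `CCN(Cc1ccc(Br)cc1)c1cccc(C(=O)N2CCc3ccc(OS(N)(=O)=O)cc3C2)c1` has not yet been measured. It differs from compound 1 in one place: (4-bromobenzyl)(ethyl)amino in place of bis(2-(dimethylamino)ethyl)amino on an aromatic carbon. Among the compounds with values here, no pair of measured compounds that differ in a single place is known, so the size of this step cannot be read from an earlier one; the two other measured compounds only show that amines carrying an ethyl group or a benzyl group span a wide range in this assay. An upward step is expected from compound 1 to compound 4, estimated as a number 25 percentage points higher from compound 1 to compound 4 (beyond the scatter), because compound 2 with its ethyl group on the amine reaches 42.5%. The estimate for compound 4 in this assay is 25%, with a range from 5% to 50%.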

Compound 4, a percentage reported as inhibition, at one concentration (the size of the read-out at that concentration, not a potency): 24.2%
Beside the measured number, compound 4's estimate is 0.8 percentage points above it; the measured number falls inside the stated range.
By their numbers in this assay, from the lowest: compounds 1 and 3 (each within the scatter of the next); then compound 4; then compound 2.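

In this assay, within the data shown here, the exchange of bis(2-(dimethylamino)ethyl)amino for (4-bromobenzyl)(ethyl)amino on an aromatic carbon, meta to a large group, gives the only single-place comparison available, with a number 24.2 percentage points higher from compound 1 to compound 4 (beyond the scatter). The result shows that what this position carries matters: the two groups have the same count of 11 heavy atoms, yet the compounds can be told apart. The change is still a composite one, replacing a group with 3 nitrogen atoms and no ring by a group with 1 nitrogen atom, 1 bromine atom and one six-membered aromatic ring of carbon only, and no measurement offers an explanation for the rise.

The compounds shown leave open whether the bromine, the aromatic ring or the ethyl group accounts for the step. An unsubstituted benzyl group or a 4-chlorobenzyl group on the same amine, or a propyl group in place of the ethyl group, would help to separate these parts.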